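The compounds below may be only part of what the source reports. "The series", "measured", "known", "first", "only" and "open" are said of these compounds alone.

Measured compounds:
compound 1, `CCC/C(=N/S(=O)(=O)c1ccc(C)cc1)OC`, 0.533 h
compound 2, `CCCC/C(=N/S(=O)(=O)c1ccc(C)cc1)OC`, 0.467 h
compound 3, `CCO/C(C)=N\S(=O)(=O)c1ccc(C)cc1`, 0.107 h

The three compounds were examined in an ADME assay on the whole organism (plasma) for pharmacokinetics, with Homo sapiens as the target, in phosphate buffer, at pH 7.4; on this read-out higher numbers stand for a longer-lived compound and lower numbers for a shorter-lived compound. Compound 1 gives 0.533 h, and compound 2 gives 0.467 h; the step between them is a 1.1-fold lower number from compound 1 to compound 2 (0.06 log units; within the scatter), so the two numbers are not told apart by this assay. The change that carries from compound 1 to compound 2 is methyl in place of hydrogen on a saturated chain carbon, three bonds along the chain from a carbon with a double bond to nitrogen. Compound 3 stands apart: in this assay compound 3 gives 0.107 h, the lowest of the three numbers, beyond the scatter of both compound 2 and compound 1. The difference between the core of compound 3 and the core of compound 1 is not broken down here.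

Compound 4, `CCO/C(CC)=N\S(=O)(=O)c1ccc(C)cc1`, has not been measured. It differs from compound 3 by methyl in place of hydrogen on a saturated chain carbon bound to a carbon with a double bond to nitrogen. Going by the values given here, this is the same kind of change as the one from compound 1 to compound 2, but not the same: there the methyl enters on a saturated chain carbon three bonds along the chain from a carbon with a double bond to nitrogen, whereas here it enters on a saturated chain carbon bound to a carbon with a double bond to nitrogen. Beside the earlier step, which stayed within the scatter, the step from compound 3 to compound 4 is expected to be a 1.7-fold higher number from compound 3 to compound 4 (0.23 log units; within the scatter), a modest rise, resting on the near-flat outcome of compound 1 to compound 2 and on the longer-chained compound 1 and compound 2 standing higher than compound 3. The estimate for compound 4 in this assay is therefore 0.18 h, with a likely range from 0.09 h to 0.4 h.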

Compound 4, half-life: 0.4 h
Beside the measured number, compound 4's estimate is 2.2-fold (0.35 log units) below it, and the stated range covers the measured number.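

In this assay, methyl in place of hydrogen on a saturated chain carbon bound to a carbon with a double bond to nitrogen gives a 3.7-fold higher number from compound 3 to compound 4 (0.57 log units; beyond the scatter). Set beside the earlier step, this shows that the change does not carry from one core to the other with a single size: the same change on two cores in this assay, a 1.1-fold lower number (0.06 log units; within the scatter) from compound 1 to compound 2 and a 3.7-fold higher number (0.57 log units; beyond the scatter) from compound 3 to compound 4, 4.3-fold (0.63 log units) apart, beyond the scatter of two such steps. It does not show what lies behind that gap: the methyl enters on a different core and also at a different place in the two steps, and two steps alone cannot separate these differences or show how the change would behave on any further core.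

The compounds shown leave open whether methyl in place of hydrogen at the same place on both cores would give steps that agree, which would tell the part of the core from the part of the place. They also leave open whether a longer chain, or an amine or a hydroxyl group, on that saturated chain carbon of compound 4 would keep the number as high as it stands there or move it in either direction.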